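A few compounds are considered here, and "the series" means these few. Any claim that something is new, unique, unknown or untested is made for them only; others in the source may bear on it.

Of the compounds shown here, three have so far been tested in an assay for inhibition of Thromboxane-A synthase (Homo sapiens), using microsomes; a higher number here means a weaker inhibitor, a lower number a stronger inhibitor. Compound 1 `N#Cc1ccc(C2OCC(C/C=C\CCC(=O)O)C(c3cccnc3)O2)cc1` gives 24 nM. Compound 2 `N#Cc1ccccc1C1OCC(C/C=C\CCC(=O)O)C(c2cccnc2)O1` gives 54 nM, a shift of a 2.3-fold higher number from compound 1 to compound 2 (0.35 log units; beyond the scatter). Compound 3 `O=C(O)CC/C=C\CC1COC(c2ccc([N+](=O)[O-])cc2)OC1c1cccnc1` gives 39 nM. Compound 3 stands second highest of the three numbers, but neither the step of a 1.6-fold higher number from compound 1 to compound 3 (0.21 log units; within the scatter) nor the step of a 1.4-fold lower number from compound 2 to compound 3 (0.14 log units; within the scatter) reaches beyond the scatter, so compound 3 cannot be set apart from either of its neighbours.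

Compound 4 `O=C(O)CC/C=C\CC1COC(c2ccc(Cl)cc2Cl)OC1c1cccnc1` has not yet been measured. It differs from compound 3 by 2,4-dichlorophenyl in place of 4-nitrophenyl on a saturated ring carbon. The steps that speak to this change are those that altered the same aryl group: one was modest and two lay within the scatter. An expected step of a 1.0-fold higher number from compound 3 to compound 4 (0.01 log units; within the scatter) is therefore assumed, because the change a 2.3-fold higher number from compound 1 to compound 2 (0.35 log units; beyond the scatter) was the largest seen on this aryl group and even that was modest. Compound 4 is estimated at 40 nM. The expected range for compound 4 runs from 15 nM to 110 nM.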

Compound 4, half-maximal inhibitory concentration: 42 nM
Compound 4: the middle estimate sits 1.1-fold (0.02 log units) below what was measured, within the range that was stated.
By their numbers in this assay, from the lowest: compounds 1, 3, 4 and 2 (each within the scatter of the next, the first and the last beyond it).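

Placing 2,4-dichlorophenyl on the saturated ring carbon between the two ring oxygen atoms gives a reading in this assay that cannot be told apart from that of compound 3 (a 1.1-fold higher number from compound 3 to compound 4 (0.03 log units; within the scatter)), even though the 4-nitrophenyl group it replaces has hydrogen-bond acceptors and the new group has none. Compound 4 also stays within the scatter of both cyanophenyl compounds (a 1.3-fold lower number from compound 2 to compound 4 (0.11 log units; within the scatter); a 1.8-fold higher number from compound 1 to compound 4 (0.24 log units; within the scatter)), so among these four compounds an aryl group with two chlorine atoms reads no differently here from one with a nitro or nitrile group. No measurement available here accounts for this likeness.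

As far as these compounds go, it remains open how an amine or a hydroxyl group on this phenyl ring would read. The same question stands for a saturated cyclohexyl ring in place of the phenyl ring.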